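Bromo on the benzyl ring of a triazole-linked chalcone

The compounds below may be only part of what the source reports. "The series", "measured", "known", "first", "only" and "open" are said of these compounds alone.

Measured so far:
Compound 1 `O=C(/C=C/c1ccc(OCc2cn(Cc3ccccc3Br)nn2)cc1)c1ccc(Br)cc1` gives 43% in a functional assay on MIA PaCa-2 cells (Homo sapiens) for inhibition, read by MTT assay, with a stated time of 48 h, tested at 10 uM; a lower number here means less inhibition of growth, a higher number more inhibition of growth at the concentration tested.
Compound 2 `COc1ccc(C(=O)/C=C/c2ccc(OCc3cn(Cc4ccccc4)nn3)cc2)cc1` gives 68% in this assay.

Compound 2 stands highest of the two numbers in this assay; its nearest neighbour, compound 1, lies lower by a gap beyond the scatter. Among the measured compounds shown here, the two compounds differ in two places, so no single step between them can be read off, and what they show is only that the pair with the bromobenzyl and the bromophenyl ketone sits lower.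

Compound 3 `COc1ccc(C(=O)/C=C/c2ccc(OCc3cn(Cc4ccccc4Br)nn3)cc2)cc1` is compound 2 with one change: bromo in place of hydrogen on an aromatic carbon. For the measured compounds named here, no measured pair isolates this change. Going by the values given here, the only hint is compound 1, which carries the 2-bromobenzyl and gives 43%, but its second difference leaves that hint weak. The account therefore expects a modest step downward, or none beyond the scatter, from compound 2 to compound 3, written as a number 10 percentage points lower from compound 2 to compound 3 (within the scatter). On that basis compound 3 is estimated at 58%, within a range from 35% to 78%.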

Compound 3, percent growth inhibition at one concentration: 50%
Compound 3: the middle estimate sits 8 percentage points above what was measured; the range from low to high includes it.
By their numbers in this assay, from the lowest: compounds 1 and 3 (each within the scatter of the next); then compound 2.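

In this assay, the change from benzyl to 2-bromobenzyl now has a size of its own: a number 18 percentage points lower from compound 2 to compound 3 (beyond the scatter), a modest loss of growth inhibition at the concentration tested for bromo in place of hydrogen on this aromatic carbon, ortho to a large group. With the 2-bromobenzyl held constant, methoxy in place of bromo on an aromatic carbon gives a number 7 percentage points higher from compound 1 to compound 3 (within the scatter), so of the two places that separate the earlier pair, only the benzyl change has so far shown a step beyond the scatter. Nothing available here accounts for either step.

As far as these compounds go, it remains open whether this loss is particular to bromo, since a fluoro, a methyl, a methoxy or an amine on the same carbon might give a different number, and whether bromo on another carbon of that ring would behave alike. From the compounds shown here alone, it is also open whether the step carries over to the shared core with bromo in place of methoxy, as compound 1 has no partner here bearing plain benzyl.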